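Methyl in Place of 4-Chlorophenyl on the Ring Amide Carbonyl

The source may hold more compounds than are shown below. What is called first, only, known or untested is meant among the compounds shown, and "the series" means these compounds.

Measured compounds:
Compound 1, `CC(=O)N1c2ccccc2CCC1C(=O)Nc1cc(C(F)(F)F)cc(C(F)(F)F)c1`: > 70000 nM
Compound 2, `O=C(Nc1cc(C(F)(F)F)cc(C(F)(F)F)c1)C1CCc2ccccc2N1C(=O)c1ccc(Cl)cc1`: 2220 nM
Compound 3, `O=C(Nc1ccccc1C(F)(F)F)C1CCc2ccccc2N1C(=O)c1ccc(Cl)cc1`: 839 nM

In a functional assay on HCT-15 cells (Homo sapiens) for cytotoxicity, read by sulforhodamine B assay, with a stated time of 72 h (a lower number here means a stronger inhibitor of growth, a higher number a weaker inhibitor of growth), compound 1 reports only a limit, > 70000 nM, and not a number. Compound 2 gives 2220 nM. The change between them is methyl in place of 4-chlorophenyl on a carbonyl carbon, and it produced an at least 31-fold higher number from compound 2 to compound 1 (1.49 log units; beyond the scatter); this size is bounded by the limit of > 70000 nM in this assay, at which 1 of the 3 values shown sits. Compound 3, with 839 nM, has the lowest number of the two measured values, and it differs from compound 2 in more than one place, so the difference between the two cores is not broken down here.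

Compound 4 is `CC(=O)N1c2ccccc2CCC1C(=O)Nc1ccccc1C(F)(F)F`. Among the compounds with values here, it differs from compound 3 by methyl in place of 4-chlorophenyl on a carbonyl carbon, which is the same change as the one from compound 2 to compound 1, made at a place described in the same words.

Given that earlier step, the step into compound 4 is expected to be a 36-fold higher number from compound 3 to compound 4 (1.55 log units; beyond the scatter) because an at least 31-fold higher number from compound 2 to compound 1 (1.49 log units; beyond the scatter) was large. Compound 4 is therefore expected to give about 30000 nM in this assay, plausibly between 8000 nM and 90000 nM, with a real chance that only a limit is reported.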

Compound 4, concentration for 50% growth inhibition: > 80000 nM
Compound 4 ended at the assay's limit (the forecaster's own chance of this, stated with the estimate: 45%); middle value at least 2.6-fold (0.42 log units) away from the limit.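

In this assay, compound 4 reports > 80000 nM, which is a limit of the assay and not a number. Methyl in place of 4-chlorophenyl on a carbonyl carbon gave an at least 95-fold higher number from compound 3 to compound 4 (1.97 log units; beyond the scatter), so the loss of growth inhibition seen on the first core also appeared on this one. The change therefore carried over in direction and remained large, but neither step has an exact size, and the data do not show whether the core alters its extent: the same change on two cores in this assay, an at least 31-fold higher number (1.49 log units; beyond the scatter) from compound 2 to compound 1 and an at least 95-fold higher number (1.97 log units; beyond the scatter) from compound 3 to compound 4; the limit leaves it open whether they differ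

The compounds shown leave open whether the difference rests with the chlorine or with the aromatic ring of the 4-chlorophenyl group, as that carbonyl carries only this group or methyl. On these data alone, how a plain phenyl, a longer chain such as butyl, or a phenyl bearing an amine would read at that place in this assay also remains open, as does the outcome of this change on cores with other groups on the anilide ring.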